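Chloro for methylamino on the saturated ring carbon

The source may hold more compounds than are shown below. What is called first, only, known or untested is meant among the compounds shown, and "the series" means these compounds.

Measured so far:
- compound 1 `CC[C@H]1C[C@@H](c2c(OC)cccc2OC)N(Cc2ccc(OC(F)(F)F)cc2)C1=O`, in a functional assay on CHO cells for antagonist activity at Orexin/Hypocretin receptor type 1 (Homo sapiens), read by FLIPR and calcium flux (a higher number here means a weaker inhibitor, a lower number a stronger inhibitor), compound 1 gives 619 nM
- compound 2 `CN[C@@H]1C[C@@H](c2c(OC)cccc2OC)N(Cc2ccc(OC(F)(F)F)cc2)C1=O`, in this assay compound 2 gives 2400 nM

Compound 2 gives the higher of the two numbers in this assay; compound 1 gives the lower number, and the gap between them lies beyond the usual scatter of this measurement. No other comparisons are available for the series.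

Compound 3 `COc1cccc(OC)c1[C@@H]1C[C@@H](Cl)C(=O)N1Cc1ccc(OC(F)(F)F)cc1` differs from compound 2 in one place: chloro in place of methylamino on a saturated ring carbon. The group that leaves carries both a hydrogen-bond donor and an acceptor; the group that enters carries neither. Among the measured compounds shown here, no measured pair shows this exchange, so the size of the step can only be guessed from the two numbers at hand.

The expectation for compound 3 is a move toward a lower number, of modest size, a 2.0-fold lower number from compound 2 to compound 3 (0.30 log units; within the scatter), with little confidence in the direction. Compound 3 is estimated at 1200 nM, with a range from 350 nM to 4500 nM.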

Compound 3, half-maximal inhibitory concentration: 177 nM
Compound 3: the middle estimate sits 6.8-fold (0.83 log units) above what was measured; measured number outside the range, below it.
By their numbers in this assay, from the lowest: compound 3; then compound 1; then compound 2.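

Chloro in place of methylamino on this saturated ring carbon gives, in this assay, a 14-fold lower number from compound 2 to compound 3 (1.13 log units; beyond the scatter), so the substituent at this position has a strong bearing on the number, and neither a hydrogen-bond donor nor an acceptor on this carbon is needed for a low value. Compound 1 gives 619 nM and compound 3 a lower 177 nM, so, of the substituents shown here, chloro gives the lowest number at this position. No measurement at hand accounts for the size of the step.

The compounds shown do not separate the loss of the amine hydrogen from the arrival of chlorine itself. Dimethylamino, which keeps the nitrogen without its hydrogen, and fluoro or bromo, which are other halogens, would address that question.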